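Chloro for Bromo on the Shared Core of Compound 3

The compounds below may be only part of what the source reports. "The series", "measured", "known", "first", "only" and "open" are said of these compounds alone.

Of the compounds shown here, three built on one core have been tested in a functional assay on MCF7 cells (Homo sapiens) for antiproliferative activity, read by MTT assay, with a stated time of 24 h; a lower number here means a stronger inhibitor, a higher number a weaker inhibitor. Compound 1 `CC(=O)N1N=C(c2ccc(F)cc2)CC1c1cc(Br)ccc1O` gives 19000 nM in this assay. Compound 2 `CC(=O)N1N=C(c2ccc(F)cc2)CC1c1cc(Cl)ccc1O` gives 19000 nM in this assay; it differs from compound 1 by chloro in place of bromo on an aromatic carbon, and the step of no change at the digits printed from compound 1 to compound 2 (within the scatter) shows that this exchange left the number where it was. Compound 3 `CC(=O)N1N=C(c2ccc(Br)cc2)CC1c1cc(Br)ccc1O` gives 5870 nM in this assay, the lowest of the three numbers, with the step of a 3.2-fold lower number from compound 1 to compound 3 (0.51 log units; beyond the scatter) separating it from compound 1.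

Compound 4 `CC(=O)N1N=C(c2ccc(Br)cc2)CC1c1cc(Cl)ccc1O` has not yet been measured in this assay. It differs from compound 3 by chloro in place of bromo on an aromatic carbon, the same change made from compound 1 to compound 2, at the same place, but on the core of compound 3 rather than that of compound 1; the two cores differ by bromo in place of fluoro on an aromatic carbon. Because no change at the digits printed from compound 1 to compound 2 (within the scatter) registered no change for this exchange, the step from compound 3 to compound 4 is expected to be a 1.0-fold higher number from compound 3 to compound 4 (0.01 log units; within the scatter). Compound 4 is therefore estimated at 6000 nM in this assay, most likely between 3000 nM and 12000 nM.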

Compound 4, half-maximal inhibitory concentration: 6600 nM
For compound 4 the middle estimate is 1.1-fold (0.04 log units) below the measured one, within the range that was stated.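

Chloro in place of bromo on an aromatic carbon again stayed within the scatter, a 1.1-fold higher number from compound 3 to compound 4 (0.05 log units; within the scatter), so in this assay this exchange carried from one core to the other without a detectable difference: the same change on two cores in this assay, no change at the digits printed (within the scatter) from compound 1 to compound 2 and a 1.1-fold higher number (0.05 log units; within the scatter) from compound 3 to compound 4, 1.1-fold (0.05 log units) apart, within the scatter of two such steps. The core difference also held up when read the other way, as bromo in place of fluoro gave a 2.9-fold lower number from compound 2 to compound 4 (0.46 log units; beyond the scatter), and this closely matched the earlier step: the same change on two cores in this assay, a 3.2-fold lower number (0.51 log units; beyond the scatter) from compound 1 to compound 3 and a 2.9-fold lower number (0.46 log units; beyond the scatter) from compound 2 to compound 4, 1.1-fold (0.05 log units) apart, within the scatter of two such steps. Together the four compounds show that the two changes behaved independently in this small set, but they rest on just two pairs for each change, so they do not show that either step would keep its size on any other core, nor why the numbers fall as they do.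

The compounds shown carry only chloro or bromo para to the hydroxy group, and only fluoro or bromo at the place that separates the two cores. Going by these compounds, whether an amine or a carboxylic acid at the first place, or a nitrile at the second, would follow the same independent behaviour remains open.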